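Swapping Acetyl for Methylsulfanyl in Two Growth Inhibitors

A few compounds are considered here, and "the series" means these few. Any claim that something is new, unique, unknown or untested is made for them only; others in the source may bear on it.

Compound 1 `CC(=O)c1ccc(/C=C(/Sc2ccc(C)cc2)C(=O)c2ccc(Br)cc2)cc1`: 50000 nM
Compound 2 `Cc1ccc(CS/C(=C/c2ccc(O)c(O)c2O)C(=O)c2ccc(Cl)cc2)cc1`: 50000 nM

In a functional assay on DU-145 cells (Homo sapiens) for inhibition, read by trypan blue exclusion, with a stated time of 96 h (on this read-out higher numbers stand for weaker inhibition of growth and lower numbers for stronger inhibition of growth), compound 1 gives 50000 nM. In this assay compound 2 gives 50000 nM. Among the compounds with values here, compound 1 therefore stands level with compound 2, the only other measured compound, and the two values lie within the scatter of each other, so nothing separates them on these numbers. Compound 3 `CSc1ccc(/C=C(/Sc2ccc(C)cc2)C(=O)c2ccc(Br)cc2)cc1` has not yet been measured. It differs from compound 1 in one place: methylsulfanyl in place of acetyl on an aromatic carbon. Within the data shown here, no measured pair shows this change, so its effect on growth inhibition is unknown from the data at hand. With both measured compounds sitting at the same level, only a small step is expected: a 1.3-fold lower number from compound 1 to compound 3 (0.10 log units; within the scatter), in no clear direction beyond the scatter. Compound 3 is accordingly estimated to give 40000 nM in this assay, within a range of 12000 nM to 100000 nM.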

Compound 3, concentration for 50% growth inhibition: 50000 nM
Compound 3: the middle estimate sits 1.3-fold (0.10 log units) below what was measured; the range from low to high includes it.
By their numbers in this assay, from the lowest: compounds 1, 2 and 3 (each within the scatter of the next).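

Within the data shown here, this is the first matched pair: in this assay, methylsulfanyl in place of acetyl on an aromatic carbon gives no change at the digits printed from compound 1 to compound 3 (within the scatter). On these numbers, 4-acetylphenyl and 4-(methylsulfanyl)phenyl cannot be told apart at this position of the shared core, so the carbonyl of the acetyl group is shown to make no difference that this read-out can detect in this pair. Nothing among the available data offers a reason for this result.

On these data alone, it remains open whether this position responds to any group at all, since an amine, a carboxylic acid or a longer alkyl chain in the same place might read differently. As far as these compounds go, it is also open whether the same swap would read alike with chloro instead of bromo on the core.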